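Cyclohexylsulfanyl in Place of 4-Methylpiperidin-1-yl

The source may hold more compounds than are shown below. What is called first, only, known or untested is meant among the compounds shown, and "the series" means these compounds.

Of the compounds shown here, three sharing one core have been measured in an assay on cells for antagonist activity at transient receptor potential cation channel subfamily V member 1 (Homo sapiens), read by FLIPR and calcium flux, with a stated time of 6 min; on this read-out higher numbers stand for weaker inhibition and lower numbers for stronger inhibition. Compound 1 `CC(C)CCOc1nc(C(C)(C)C)ccc1CNC(=O)C(C)c1ccc(NS(C)(=O)=O)c(F)c1` gives 0.8 nM, compound 2 `COCCCOc1nc(C(C)(C)C)ccc1CNC(=O)C(C)c1ccc(NS(C)(=O)=O)c(F)c1` gives 5.6 nM, and compound 3 `CC1CCN(c2cc(C(C)(C)C)ccc2CNC(=O)C(C)c2ccc(NS(C)(=O)=O)c(F)c2)CC1` gives 0.7 nM. Going by the values given here, the only single-point step among them, a 7.0-fold higher number from compound 1 to compound 2 (0.85 log units; beyond the scatter), concerns a chain group and not the ring position changed here. Compound 3 and compound 1 lie within the scatter of each other, while compound 2 stands apart with a clearly higher number. Compound 4 `CC(C(=O)NCc1ccc(C(C)(C)C)cc1SC1CCCCC1)c1ccc(NS(C)(=O)=O)c(F)c1` differs from compound 3 by cyclohexylsulfanyl in place of 4-methylpiperidin-1-yl on an aromatic carbon. Among the compounds with values here, no measured step touches this position, so the only guide is that an oxygen-linked chain in compound 1 and a nitrogen-linked ring in compound 3 give numbers within the scatter of each other, which suggests the core tolerates varied groups there; a sulfur-linked ring remains an untested kind of change. For compound 4 a step of a 2.1-fold higher number from compound 3 to compound 4 (0.33 log units; beyond the scatter) is expected, a change within the scatter. The estimate for compound 4 in this assay is 1.5 nM, with a range from 0.4 nM to 6 nM.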

Compound 4, inhibition constant: 7.4 nM
For compound 4 the middle estimate is 4.9-fold (0.69 log units) below the measured one; the whole stated range lies below it.
By their numbers in this assay, from the lowest: compounds 3 and 1 (each within the scatter of the next); then compounds 2 and 4 (each within the scatter of the next).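

Replacing 4-methylpiperidin-1-yl with cyclohexylsulfanyl gives an 11-fold higher number from compound 3 to compound 4 (1.02 log units; beyond the scatter) in this assay even though the two groups have much in common, so this position is sensitive to more than the simple counts of its substituent. Each group has 7 heavy atoms, one six-membered non-aromatic ring, no hydrogen-bond donors and one hydrogen-bond acceptor, so those counts cannot account for the step. The groups differ in atom makeup, with sulfur replacing nitrogen, but no measurement here explains why the number rises.

The shown compounds leave open whether the sulfur atom or the carbon-only ring matters more. Cyclohexylamino or cyclohexyloxy at this position would test the linking atom, while piperidin-1-yl without the methyl group would test the methyl group.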